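From a carboxy chain end to a hydroxy ether chain

This account rests on a few compounds, and the source may have more. Where it says the series, first, only, none or still open, it means among the compounds named here.

Compound 3 `O=C(O)CCCCOc1ccc2c(=O)c(-c3ccc(O)cc3)coc2c1` in an assay (Cricetulus griseus) for inhibition of aldehyde dehydrogenase, mitochondrial (Homo sapiens) (a lower number here means a stronger inhibitor, a higher number a weaker inhibitor), gives 100 nM, the second highest of the three numbers. Its nearest neighbour is compound 2 `O=C(O)CCCCCCCOc1ccc2c(=O)c(-c3ccc(O)cc3)coc2c1`, which gives 40 nM, and its furthest is compound 1 `O=c1c(-c2ccc(O)cc2)coc2cc(OCCCCCCCCCO)ccc12`, which gives 700 nM. The step of a 2.5-fold higher number from compound 2 to compound 3 (0.40 log units; beyond the scatter) is modest, while a 7.0-fold lower number from compound 1 to compound 3 (0.85 log units; beyond the scatter) is larger. Compound 4 `O=c1c(-c2ccc(O)cc2)coc2cc(OCCOCCOCCO)ccc12` is the unmeasured partner. Its change from compound 3 is 2-(2-hydroxyethoxy)ethoxy in place of 2-carboxyethyl on a saturated chain carbon, two bonds along the chain from an oxygen on an aromatic ring. Among the compounds with values here, two measured steps bear on this, an 18-fold lower number from compound 1 to compound 2 (1.24 log units; beyond the scatter) and a 7.0-fold lower number from compound 1 to compound 3 (0.85 log units; beyond the scatter); both place carboxy where a 2-hydroxyethyl or 5-hydroxypentyl group stood, and both give a lower number beyond the scatter. Compound 4 goes the other way, with 2-carboxyethyl leaving and 2-(2-hydroxyethoxy)ethoxy entering, so a higher number in this assay is expected for compound 4, by a step of about a 6.0-fold higher number from compound 3 to compound 4 (0.78 log units; beyond the scatter). Compound 4 is therefore estimated at 600 nM, with a range from 200 nM to 2000 nM.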

Compound 4, half-maximal inhibitory concentration: 40 nM
Compound 4: the middle estimate sits 15-fold (1.18 log units) above what was measured, outside the stated range (below it).
By their numbers in this assay, from the lowest: compounds 2 and 4 (each within the scatter of the next); then compound 3; then compound 1.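

In this assay, a carboxy chain end turns out not to be needed for a low number: 2-(2-hydroxyethoxy)ethoxy in place of 2-carboxyethyl gives a 2.5-fold lower number from compound 3 to compound 4 (0.40 log units; beyond the scatter), and 2-(2-hydroxyethoxy)ethoxy in place of 5-carboxypentyl gives no change at the digits printed from compound 2 to compound 4 (within the scatter). Two chains that both end in hydroxy can also stand far apart, since 2-(2-hydroxyethoxy)ethoxy in place of 7-hydroxyheptyl gives an 18-fold lower number from compound 1 to compound 4 (1.24 log units; beyond the scatter). Nothing measured here accounts for this result.

On these data alone, what stays open is whether the ether oxygens or the chain length carry the last step, as that change alters both at once. A chain of the same ether kind ending in an amine, or a longer chain of repeating ether units, would show how far this holds.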